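The compounds below may be only part of what the source reports. "The series", "measured", "known", "first", "only" and "open" are said of these compounds alone.

Working notes on the series in a toxicity assay on GES1 cells (Homo sapiens) for inhibition, read by MTT assay, with a stated time of 72 h; on this read-out higher numbers stand for weaker inhibition and lower numbers for stronger inhibition. Compound 1 `Cc1cc(N2CC[C@@H](C)[C@@H](N(C)c3ncnc4[nH]ccc34)C2)n2nc(SCC3CC3)nc2n1`, carrying cyclopropyl, gives 27900 nM. Compound 3 `Cc1cc(N2CC[C@@H](C)[C@@H](N(C)c3ncnc4[nH]ccc34)C2)n2nc(SCC3CCCCC3)nc2n1`, carrying cyclohexyl, gives 98200 nM, the higher of the two actual numbers. Compound 2 `Cc1cc(N2CC[C@@H](C)[C@@H](N(C)c3ncnc4[nH]ccc34)C2)n2nc(SCc3csc4ccc(Cl)cc34)nc2n1`, carrying 5-chloro-1-benzothiophen-3-yl, reads > 100000 nM, which is a limit of the assay and not a number.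

Compound 4 `Cc1cc(N2CC[C@@H](C)[C@@H](N(C)c3ncnc4[nH]ccc34)C2)n2nc(SCc3ccc(Br)cc3)nc2n1` follows from compound 3 by one change: 4-bromophenyl in place of cyclohexyl on a saturated chain carbon bound to a sulfur. Within the data shown here, two measured steps bear on it: a 3.5-fold higher number from compound 1 to compound 3 (0.55 log units; beyond the scatter) and an at least 3.5-fold higher number from compound 1 to compound 2 (0.55 log units; beyond the scatter). Both are modest and upward, so the two larger groups point the same way. The closest comparison is an at least 1.0-fold lower number from compound 2 to compound 3 (0.00 log units; that floor lies within the scatter), which leaves cyclohexyl and the aromatic group unseparated. Any upward move is also capped by the limit of > 100000 nM in this assay, at which 1 of the 3 values shown sits.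

The expected step is a 1.2-fold lower number from compound 3 to compound 4 (0.06 log units; within the scatter), with no change beyond the scatter anticipated. For compound 4 the estimate is 85000 nM, with an expected range of 35000 nM to 150000 nM.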

Compound 4, half-maximal inhibitory concentration: 55600 nM
The estimate for compound 4 lay 1.5-fold (0.18 log units) above the measured number, and the stated range covers the measured number.
By their numbers in this assay, from the lowest: compounds 1, 4 and 3 (each within the scatter of the next, the first and the last beyond it). At a limit, above all of these: compound 2.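

Among these compounds, compound 4 gives the first actual number for an aromatic group at this place in this assay; the other aromatic example, compound 2, reads only as a limit. Replacing cyclohexyl gives a 1.8-fold lower number from compound 3 to compound 4 (0.25 log units; within the scatter) and replacing cyclopropyl gives a 2.0-fold higher number from compound 1 to compound 4 (0.30 log units; within the scatter), so 4-bromophenyl is separated from neither group, although those two are separated from each other. Going by these compounds, replacing 5-chloro-1-benzothiophen-3-yl gives an at least 1.7-fold lower number from compound 2 to compound 4 (0.25 log units; that floor lies within the scatter), and that comparison remains open-ended at the top: the limit of > 100000 nM in this assay, at which 1 of the 4 values shown sits.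

The compounds shown do not separate the effect of the bromine from that of the phenyl ring in 4-bromophenyl. On these data alone, how an amine or a carboxylic acid on the group at this place, or a longer chain on the sulfur, would read also remains open.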